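Methoxy Added to the Styryl Ring of a Fluorinated Chalcone

A few compounds are considered here, and "the series" means these few. Any claim that something is new, unique, unknown or untested is made for them only; others in the source may bear on it.

Compound 1 `COc1cc(OC)c(OC)cc1/C=C/C(=O)c1ccccc1F`: 79 nM
Compound 2 `COc1ccc(C(=O)/C=C/c2ccc(OC)cc2OC)c(F)c1`: > 100000 nM

In a functional assay on A549 cells (Homo sapiens) for cytotoxicity, read by MTT assay, with a stated time of 72 h (a higher number here means a weaker inhibitor, a lower number a stronger inhibitor), compound 1 gives 79 nM. Compound 2 reaches only a limit of this assay, > 100000 nM (the limit of > 100000 nM in this assay, at which 1 of the 2 values shown sits). For the measured compounds named here, compound 1 and compound 2 differ in more than one place, so their two values show no single step.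

Compound 3 `COc1ccc(C(=O)/C=C/c2cc(OC)c(OC)cc2OC)c(F)c1` differs from compound 2 by methoxy in place of hydrogen on an aromatic carbon. The change is expected to strengthen inhibition in this assay, though its size is uncertain. The estimated step is an at least 50-fold lower number from compound 2 to compound 3 (1.69 log units; beyond the scatter). For compound 3 in this assay the estimate is 2000 nM, ranging from 100 nM to 100000 nM.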

Compound 3, half-maximal inhibitory concentration: 202 nM
Compound 3: the middle estimate sits 9.9-fold (1.00 log units) above what was measured; measured number inside the range.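

In this assay, methoxy on this aromatic carbon, para to a methoxy group, separates a measurable compound from an inactive one, with an at least 490-fold lower number from compound 2 to compound 3 (2.69 log units; beyond the scatter) as the step. The value for compound 2 is a limit, not a number: the limit of > 100000 nM in this assay, at which 1 of the 3 values shown sits. The same exchange at a site on the other aromatic ring is a much smaller change, with a 2.6-fold higher number from compound 1 to compound 3 (0.41 log units; beyond the scatter) as the step, and it leaves compound 3 the weaker of that pair. As far as these compounds go, whether an amine or a hydroxyl in place of the new methoxy would keep this activity stays open.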